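The compounds below may be only part of what the source reports. "The series", "measured", "known", "first", "only" and "open" are said of these compounds alone.

Measured in a physicochemical assay, read by spectrophotometry, with a stated time of 6 min; a higher number here means a weaker inhibitor, a lower number a stronger inhibitor:
- compound 1 `O=C(CCCc1nc2ccccc2c(=O)[nH]1)N/N=C/c1cc(O)c(O)c(O)c1`: 40000000 nM
- compound 2 `COc1cc(/C=N/NC(=O)CCc2nc3ccccc3c(=O)[nH]2)ccc1O`: 95000000 nM

Compound 1 holds the lower of these two numbers, and the gap to compound 2 lies beyond the scatter. Compound 3 `O=C(CCCc1nc2ccccc2c(=O)[nH]1)N/N=C/c1ccc(O)c(O)c1` is still unmeasured. It carries hydrogen in place of hydroxy on an aromatic carbon, 3,4,5-trihydroxyphenyl to 3,4-dihydroxyphenyl: hydrogen in place of hydroxy on an aromatic carbon. Among the measured compounds shown here, no measured pair shows this change alone, so the expectation is a judgement. A modest move towards a higher number, meaning weaker inhibition in this assay, is expected, as the estimated 1.8-fold higher number from compound 1 to compound 3 (0.24 log units; within the scatter). For compound 3 the estimate is 70000000 nM, with an expected range of 30000000 nM to 160000000 nM.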

Compound 3, half-maximal inhibitory concentration: 50000000 nM
Compound 3: the middle estimate sits 1.4-fold (0.15 log units) above what was measured; the range from low to high includes it.
By their numbers in this assay, from the lowest: compounds 1, 3 and 2 (each within the scatter of the next, the first and the last beyond it).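

In this assay, among the compounds shown here, hydrogen in place of hydroxy on an aromatic carbon gives a 1.3-fold higher number from compound 1 to compound 3 (0.10 log units; within the scatter), the first direct reading of this change. At this position, ortho to one hydroxy group and meta to another, the 3,4,5-trihydroxyphenyl and 3,4-dihydroxyphenyl compounds cannot be told apart in this assay. No supporting data explain this result.

Going by these compounds, whether an amine or a carboxylic acid at this position would depart from hydroxy and hydrogen remains open. The effect of the chain alone also remains unresolved, since compound 2 differs from compound 3 in more than one place.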